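Swapping an ethyl for a methylamino group

The source may report more compounds than this note shows. Statements on the series, on what has been measured and on what is new or still open speak of the compounds shown alone.

Of the compounds shown here, three built on a shared core have been tested in a functional assay on the whole organism for inhibition, with Rattus norvegicus as the target, at a dose of 1 mg/kg by the oral route; on this read-out lower numbers stand for a weaker effect and higher numbers for a stronger effect at the one dose given. Compound 3 `CCc1ccc(-c2cccc(C(=O)Nc3nn[nH]n3)n2)cc1` gives 39%, the highest number of the three. Compound 1 `CNc1ccc(-c2cc(OC)cc(C(=O)Nc3nn[nH]n3)n2)cc1` gives 35%, which lies within the scatter of compound 3, so the two cannot be ranked. Within the data shown here, compound 2 `COc1ccc(-c2cccc(C(=O)Nc3nn[nH]n3)n2)cc1` gives 12%, clearly lower; the single step of a number 27 percentage points higher from compound 2 to compound 3 (beyond the scatter) is the only one measured so far.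

Compound 4 `CNc1ccc(-c2cccc(C(=O)Nc3nn[nH]n3)n2)cc1` differs from compound 3 in one place: methylamino in place of ethyl on an aromatic carbon. Among the measured compounds shown here, no measured step swaps exactly these two groups, so the ethyl-for-methoxy step gives only indirect guidance. The closest reference is compound 1, which also carries a methylamino group on its outer ring and sits within the scatter of compound 3.

The step of a number 5 percentage points lower from compound 3 to compound 4 (within the scatter) is expected to stay within the scatter, because compound 1 with its methylamino group gives 35%. Compound 4 is therefore estimated at 34%, with a range from 16% to 52%.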

Compound 4, a percentage reported as inhibition, in the whole organism at one dose (the size of the read-out at that dose, not a potency): 71%
Estimate against measurement, compound 4: 37 percentage points below; measured number above the stated range.
By their numbers in this assay, from the lowest: compound 2; then compounds 1 and 3 (each within the scatter of the next); then compound 4.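

At the outer-ring carbon para to a large group, the choice of group matters greatly: methylamino in place of ethyl gives a number 32 percentage points higher from compound 3 to compound 4 (beyond the scatter), even though the two groups have the same count of heavy atoms, and methylamino in place of methoxy gives a number 59 percentage points higher from compound 2 to compound 4 (beyond the scatter). A second place matters too: with methylamino held constant, dropping the methoxy group gives a number 36 percentage points higher from compound 1 to compound 4 (beyond the scatter), so the closeness of compound 1 to compound 3 said little about methylamino itself. Among these compounds, nothing measured here explains why either change moves the number so far.

The compounds shown leave open whether a plain amine or a dimethylamino group at the outer-ring carbon would match methylamino. They also leave open how compound 4 would behave at doses other than the single one given.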